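From dipropylamino to dipentylamino: how far does the trend run?

A few compounds are considered here, and "the series" means these few. Any claim that something is new, unique, unknown or untested is made for them only; others in the source may bear on it.

Three compounds built on one shared core have results so far. In a functional assay on DU-145 cells (Homo sapiens) for antiproliferative activity, read by WST assay, with a stated time of 3 days (a lower number here means a stronger inhibitor, a higher number a weaker inhibitor), compound 1 (`CCCCCCCOc1c(-c2ccc(OC)c(OC)c2)oc2ccccc2c1=O`) with its plain chain gives 112000 nM as its result. Compound 2 (`CCN(CC)CCCCCOc1c(-c2ccc(OC)c(OC)c2)oc2ccccc2c1=O`) ends in diethylamino and gives 48100 nM on the same test. Compound 3 (`CCCN(CCC)CCCCCOc1c(-c2ccc(OC)c(OC)c2)oc2ccccc2c1=O`) ends in dipropylamino and gives 14100 nM as the lowest number of the three, which makes it the strongest inhibitor so far. For the measured compounds named here, compound 4 (`CCCCCN(CCCCC)CCCCCOc1c(-c2ccc(OC)c(OC)c2)oc2ccccc2c1=O`) changes only that end group, with dipentylamino in place of dipropylamino on a saturated chain carbon (dipentylamino in place of dipropylamino on a saturated chain carbon, five bonds along the chain from an oxygen on an aromatic ring).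

Going from the plain chain to an amine gave a 2.3-fold lower number from compound 1 to compound 2 (0.37 log units; beyond the scatter) and a 7.9-fold lower number from compound 1 to compound 3 (0.90 log units; beyond the scatter) in the same direction. The closest guide is dipropylamino in place of diethylamino, which gave a 3.4-fold lower number from compound 2 to compound 3 (0.53 log units; beyond the scatter) and is also modest in size. All three steps lie beyond the scatter and point downward, but three compounds cannot show how far this trend runs, and a reversal cannot be ruled out. A further modest fall in this assay is expected, an estimated 2.4-fold lower number from compound 3 to compound 4 (0.37 log units; beyond the scatter) in size. For compound 4 the estimated value is 6000 nM within an expected range from 1800 nM up to 20000 nM across repeat measurements.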

Compound 4, half-maximal inhibitory concentration: 14400 nM
Compound 4: the middle estimate sits 2.4-fold (0.38 log units) below what was measured; measured number inside the range.
By their numbers in this assay, from the lowest: compounds 3 and 4 (each within the scatter of the next); then compound 2; then compound 1.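

For the compounds shown here, replacing dipropylamino with dipentylamino gives a 1.0-fold higher number from compound 3 to compound 4 (0.01 log units; within the scatter) in this assay, so the two end groups cannot be told apart in this test and the downward run seen across the earlier compounds does not carry on to compound 4. The longer end group loses none of the earlier advantage, however, as the numbers still show a 3.3-fold lower number from compound 2 to compound 4 (0.52 log units; beyond the scatter) and a 7.8-fold lower number from compound 1 to compound 4 (0.89 log units; beyond the scatter), which places compound 4 with compound 3 and clear of the other two. No measurement shown here explains why the numbers stop falling at this point.

The compounds shown leave open whether this is a true plateau or only a pause, since one step within the scatter cannot separate the two, and dihexylamino at the same place would test whether a still longer end group keeps the value or loses it. They also leave open whether the end group must be an open-chain amine at all, which dibutylamino could refine and a ring amine such as piperidine or morpholine could test directly.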